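Replacing the formylphenyl arm with a cyanopyridyl arm

The source may hold more compounds than are shown below. What is called first, only, known or untested is meant among the compounds shown, and "the series" means these compounds.

Measured so far in an assay on LM cells for displacement of a labelled ligand from Neuropeptide Y receptor type 5 (Homo sapiens); on this read-out higher numbers stand for weaker inhibition and lower numbers for stronger inhibition:
compound 1 `O=Cc1cccc(C2=NC(c3ccc(F)cc3)(c3ccc(F)cc3)CN2)c1`: 8.7 nM
compound 2 `Fc1ccc(C2(c3ccc(F)cc3)CNC(c3ccsc3)=N2)cc1`: 93 nM
compound 3 `Fc1ccc(C2(c3ccc(F)cc3)CNC(c3cccs3)=N2)cc1`: 54 nM

Compound 1 stands lowest of the three numbers, and both steps away from it raise the number beyond the scatter: a 6.2-fold higher number from compound 1 to compound 3 (0.79 log units; beyond the scatter) and an 11-fold higher number from compound 1 to compound 2 (1.03 log units; beyond the scatter). The two thiophenes differ from each other only within the scatter (a 1.7-fold lower number from compound 2 to compound 3 (0.24 log units; within the scatter)).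

Compound 4 `N#Cc1cc(C2=NC(c3ccc(F)cc3)(c3ccc(F)cc3)CN2)ccn1` changes the same position: 2-cyanopyridin-4-yl in place of 3-formylphenyl on a carbon with a double bond to nitrogen. Both measured steps bear on this, since each also exchanges the 3-formylphenyl for another ring on that carbon, and each weakened binding. Here, however, a six-membered ring carrying a hydrogen-bond acceptor is kept, so a smaller loss is expected. Compound 4 is therefore estimated at 20 nM, range 6 nM to 70 nM, a step of a 2.3-fold higher number from compound 1 to compound 4 (0.36 log units; beyond the scatter).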

Compound 4, half-maximal inhibitory concentration: 4.8 nM
Beside the measured number, compound 4's estimate is 4.2-fold (0.62 log units) above it; the measured number lies below the stated range.
By their numbers in this assay, from the lowest: compounds 4 and 1 (each within the scatter of the next); then compounds 3 and 2 (each within the scatter of the next).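

In this assay, the arm on this carbon does not depend on the formyl group or on a ring of carbon only: 2-cyanopyridin-4-yl matches 3-formylphenyl within the scatter (a 1.8-fold lower number from compound 1 to compound 4 (0.26 log units; within the scatter)). The same arm sits far from both thiophenes (an 11-fold lower number from compound 3 to compound 4 (1.05 log units; beyond the scatter); a 19-fold lower number from compound 2 to compound 4 (1.29 log units; beyond the scatter)), so the earlier losses go with those two rings rather than with every departure from 3-formylphenyl. No measurement shown here explains these differences.

As far as these compounds go, whether the nitrile or the ring nitrogen matters more stays open, and 3-cyanophenyl and plain pyridin-4-yl arms would separate them. From the compounds shown here alone, how a carboxylic acid or an amine on this ring would fare also stays open.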